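Chloro for Methoxy on a Urotensin-2 Receptor Series

The source may report more compounds than this note shows. Statements on the series, on what has been measured and on what is new or still open speak of the compounds shown alone.

Measured so far:
Compound 1, `COc1cccc(C(=O)OC(CCN(C)C)c2ccc(Cl)cc2)c1C`, gives 1950 nM
Compound 2, `Cc1c(Cl)cccc1C(=O)OC(CCN(C)C)c1ccc(Cl)cc1`, gives 1120 nM
Compound 3, `COc1cccc(C(=O)NC(CCN(C)C)c2ccc(Cl)cc2)c1C`, gives 4270 nM

All three values come from an assay on NIH3T3 cells with Urotensin-2 receptor (Homo sapiens) as the target; on this read-out higher numbers stand for an effect only at larger amounts of compound and lower numbers for an effect already at smaller amounts. Compound 1 and compound 2 differ by one change, (chloro in place of methoxy on an aromatic carbon), and that change made a 1.7-fold lower number from compound 1 to compound 2 (0.24 log units; within the scatter). Compound 3 stands highest of the three numbers; its core differs from the core of compound 1, but the difference between the two cores is not broken down here.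

Compound 4, `Cc1c(Cl)cccc1C(=O)NC(CCN(C)C)c1ccc(Cl)cc1`, has not yet been measured in this assay. Compound 4 differs from compound 3 by chloro in place of methoxy on an aromatic carbon, the same change as that from compound 1 to compound 2, made at a place described in the same words.

Because that earlier step was a 1.7-fold lower number from compound 1 to compound 2 (0.24 log units; within the scatter), the step from compound 3 to compound 4 is expected to be of similar size, a 1.6-fold lower number from compound 3 to compound 4 (0.22 log units; within the scatter), a step that stays within the usual scatter. The estimate for compound 4 in this assay is therefore 2600 nM, with an expected range from 1300 nM to 5200 nM.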

Compound 4, half-maximal effective concentration: 1740 nM
Beside the measured number, compound 4's estimate is 1.5-fold (0.17 log units) above it, within the range that was stated.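

On the second core, chloro in place of methoxy on an aromatic carbon gave a 2.5-fold lower number from compound 3 to compound 4 (0.39 log units; beyond the scatter) in this assay, while on the first core the same change gave a 1.7-fold lower number from compound 1 to compound 2 (0.24 log units; within the scatter). Although only the second of these steps lies beyond the scatter, the two do not differ from each other in any way these data can resolve: the same change on two cores in this assay, a 1.7-fold lower number (0.24 log units; within the scatter) from compound 1 to compound 2 and a 2.5-fold lower number (0.39 log units; beyond the scatter) from compound 3 to compound 4, 1.4-fold (0.15 log units) apart, within the scatter of two such steps. This shows that the change carried between these two cores in the same direction and at a similar size, but it rests on two pairs only, so it does not establish a rule for the series at large or show what lies behind the steps.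

The compounds shown leave open how a fluoro, bromo or trifluoromethyl group on that same aromatic carbon would read on either core. Also open, on these data alone, is whether the step would persist if the dimethylamino group gave way to a primary amine or the chain carrying it to a longer chain.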